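A few compounds are considered here, and "the series" means these few. Any claim that something is new, unique, unknown or untested is made for them only; others in the source may bear on it.

In a functional assay on HL-60 cells (Homo sapiens) for antiproliferative activity, read by MTT assay, with a stated time of 24 h (a higher number here means a weaker inhibitor, a lower number a stronger inhibitor), three compounds have been measured:
Compound 1 `CCCCc1oc2ccccc2c1C(=O)c1ccc(OCC(=O)NC(C)C)cc1`: 360 nM.
Compound 2 `CCCCc1oc2ccccc2c1C(=O)c1ccc(OCC(=O)N[C@@H](C)c2ccccc2)cc1`: > 50000 nM, which is a limit of the assay.
Compound 3 `CCCCc1oc2ccccc2c1C(=O)c1ccc(OCCCC(=O)N2CCCC2)cc1`: 29900 nM.

Compound 3 has the higher of the two exact numbers. The gap is an 83-fold higher number from compound 1 to compound 3 (1.92 log units; beyond the scatter). Compound 4 `CCCCc1oc2ccccc2c1C(=O)c1ccc(OCCCC(=O)N2CCCCC2)cc1` has piperidin-1-yl in place of pyrrolidin-1-yl on a carbonyl carbon. Among the compounds with values here, no measured step makes this swap. The nearest evidence is two large steps that involve wider changes, an 83-fold higher number from compound 1 to compound 3 (1.92 log units; beyond the scatter) and an at least 130-fold higher number from compound 1 to compound 2 (2.14 log units; beyond the scatter), while an at least 1.6-fold lower number from compound 2 to compound 3 (0.22 log units; that floor lies within the scatter) sets only a floor. A small change in this assay, with no favoured direction and none beyond the scatter, is therefore expected from the value of compound 3. The expected size is a 1.2-fold lower number from compound 3 to compound 4 (0.08 log units; within the scatter). For compound 4 the estimated value is 25000 nM, with an expected range from 9000 nM to 50000 nM.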

Compound 4, half-maximal inhibitory concentration: 31900 nM
Beside the measured number, compound 4's estimate is 1.3-fold (0.11 log units) below it; the measured number falls inside the stated range.
By their numbers in this assay, from the lowest: compound 1; then compounds 3 and 4 (each within the scatter of the next). At a limit, above all of these: compound 2.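

In this assay, within the data shown here, the only step measured at this place, piperidin-1-yl in place of pyrrolidin-1-yl on a carbonyl carbon, stays within the scatter (a 1.1-fold higher number from compound 3 to compound 4 (0.03 log units; within the scatter)). The larger ring does not bring back the value of compound 1 (an 89-fold higher number from compound 1 to compound 4 (1.95 log units; beyond the scatter)). Compound 2 stands at a limit, so its step sets only a floor (an at least 1.5-fold lower number from compound 2 to compound 4 (0.19 log units; that floor lies within the scatter)): the limit of > 50000 nM in this assay, at which 1 of the 4 values shown sits.

As far as these compounds go, compounds 3 and 4 differ from compound 1 in both chain and amide, so which of these carries the large step stays open. From the compounds shown here alone, whether morpholin-4-yl on this carbonyl would match the two rings also stays open.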